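This account rests on a few compounds, and the source may have more. Where it says the series, first, only, none or still open, it means among the compounds named here.

Measured compounds:

- compound 1, `O=C1C(Nc2ccc(-c3ccccc3)cc2)=CC(=O)c2ncncc21`, 900 nM
- compound 2, `COc1cc(NC2=CC(=O)c3ncncc3C2=O)cc(OC)c1OC`, 1500 nM

Both compounds were tested in a functional assay on MIA PaCa-2 cells (Homo sapiens) for cytotoxicity, read by MTT assay, with a stated time of 72 h; a lower number here means a stronger inhibitor, a higher number a weaker inhibitor. For the measured compounds named here, compound 1 gives the lowest of the two numbers, and compound 2, the nearest, sits close enough that the two values cannot be told apart; the data hold no single-point step between them. Compound 3, `CCOC(=O)c1ccc(NC2=CC(=O)c3ncncc3C2=O)cc1`, has not yet been measured. It differs from compound 1 in one place: ethoxycarbonyl in place of phenyl on an aromatic carbon. No comparison of this kind has been measured, so the size of the change cannot be read off from anything here; without that, the expectation is that compound 3 will land near the numbers already seen, with no step beyond the scatter in either direction strongly favoured. Compound 3 is therefore estimated at 1500 nM, ranging from 500 nM to 5000 nM, which means an expected step of a 1.7-fold higher number from compound 1 to compound 3 (0.22 log units; within the scatter).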

Compound 3, half-maximal inhibitory concentration: 5500 nM
Beside the measured number, compound 3's estimate is 3.7-fold (0.56 log units) below it, and the stated range ends below it.
By their numbers in this assay, from the lowest: compounds 1 and 2 (each within the scatter of the next); then compound 3.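

In this assay, replacing phenyl with ethoxycarbonyl on this aromatic carbon, para to a large group, gives a 6.1-fold higher number from compound 1 to compound 3 (0.79 log units; beyond the scatter), so what sits at this position clearly affects the result. The swap changes several things at once: a ring leaves, while a double bond outside aromatic rings and hydrogen-bond acceptors enter, and this single step cannot show which of these differences matters. Nothing measured here explains the loss of potency.

The compounds shown leave open whether a carboxylic acid, a primary amide or a methyl ester at this position would give a number closer to that of compound 1 or compound 3. They also leave open whether a different ring, such as pyridine, would keep the potency of compound 1.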